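Naphthalenesulfonamide series: amide replaced by phenylpropylamine

The source may report more compounds than this note shows. Statements on the series, on what has been measured and on what is new or still open speak of the compounds shown alone.

Compound 1 `O=C(Nc1ccc(S(=O)(=O)N2CCCCC2)c2ccccc12)c1ccccc1` carries a piperidine sulfonyl group and a benzamide on the shared core. In an assay on L1.2 cells for binding affinity to C-C chemokine receptor type 8 (Homo sapiens) (a lower number here means a stronger inhibitor, a higher number a weaker inhibitor), compound 1 reaches only a limit, > 30000 nM; this is recorded as the limit of > 30000 nM in this assay, at which 1 of the 3 values shown sits. Compound 2 `CCOC(=O)N1CCC(NS(=O)(=O)c2ccc(C(=O)NC3CCCCC3)c3ccccc23)CC1` instead bears the ethoxycarbonylpiperidinyl sulfonamide with a cyclohexyl amide, and in this assay compound 2 gives 9.5 nM. Compound 3 `CCOC(=O)N1CCC(NS(=O)(=O)c2ccc(C(=O)Nc3ccccc3C)c3ccccc23)CC1` differs from compound 2 only on the amide nitrogen, and in this assay compound 3 gives 5.21 nM. The step of a 1.8-fold lower number from compound 2 to compound 3 (0.26 log units; within the scatter) shows that exchanging the saturated ring for the aromatic one on that nitrogen leaves the number within the scatter. Compound 3 therefore holds the lowest of the two numbers, but cannot be called stronger than compound 2.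

Compound 4 `CCOC(=O)N1CCC(NS(=O)(=O)c2ccc(NCCCc3ccccc3)c3ccccc23)CC1` is not yet measured. The change is (3-phenylpropyl)amino in place of (2-methylphenyl)carbamoyl on an aromatic carbon: the carbonyl of the amide disappears and a (3-phenylpropyl)amino group sits on the aromatic carbon in its place. Among the compounds with values here, the single measured step altered only the group on the amide nitrogen and stayed within the scatter; no measured step removes the amide itself, so the expectation rests on little. The expected step of a 9.6-fold higher number from compound 3 to compound 4 (0.98 log units; beyond the scatter) is a weakening beyond the scatter. Compound 4 is expected to give 50 nM, with a range from 8 nM to 400 nM.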

Compound 4, inhibition constant: 32.1 nM
Compound 4: the middle estimate sits 1.6-fold (0.19 log units) above what was measured; the measured number falls inside the stated range.
By their numbers in this assay, from the lowest: compounds 3 and 2 (each within the scatter of the next); then compound 4. At a limit, above all of these: compound 1.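

In this assay the earlier step changed only the group on the amide nitrogen, whereas here the carbamoyl link itself is gone and (3-phenylpropyl)amino stands on the aromatic carbon para to a large group, giving a 6.2-fold higher number from compound 3 to compound 4 (0.79 log units; beyond the scatter) and a 3.4-fold higher number from compound 2 to compound 4 (0.53 log units; beyond the scatter). Both steps are modest but beyond the scatter, so this position keeps measurable binding without the amide carbonyl, at a real but limited cost, even though the entering group has a flexible chain where the leaving group had the carbonyl and an aromatic ring or cyclohexyl directly on the nitrogen. Nothing at hand gives a reason for the size of these steps.

The swap changes the carbonyl and the chain at once, so the compounds shown do not separate the loss of the carbonyl from the spacing of the phenyl ring. Open, as far as these compounds go, are a shorter 2-phenylethylamino or a longer 4-phenylbutylamino group at this position, an N-methyl tertiary amine in place of the secondary nitrogen, and a methyl on the phenyl ring of the chain, matching the 2-methylphenyl of compound 3.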